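The compounds below may be only part of what the source reports. "The series", "measured", "known", "first", "only" and "open" are said of these compounds alone.

Measured so far in a functional assay on A549 cells (Homo sapiens) for cytotoxicity, read by MTT assay, with a stated time of 72 h; a higher number here means a weaker inhibitor, a lower number a stronger inhibitor:
compound 1 `CN(C)CCn1cnnc1-c1cc(Oc2ccc(NC(=O)N/N=C/c3c[nH]c4ccccc34)cc2F)ccn1` gives 820 nM
compound 2 `CN(C)CCn1cnnc1-c1cc(Oc2ccc(NC(=O)N/N=C/c3ccccc3)cc2F)ccn1` gives 1860 nM

Among the measured compounds shown here, compound 2 stands as the higher of the two numbers in this assay, the only comparison being a 2.3-fold higher number from compound 1 to compound 2 (0.36 log units; beyond the scatter). Compound 3 `CN(C)CCn1cnnc1-c1cc(Oc2ccc(NC(=O)N/N=C/c3cccc(Br)c3)cc2F)ccn1` differs from compound 2 by bromo in place of hydrogen on an aromatic carbon.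

For the measured compounds named here, the single measured step, a 2.3-fold higher number from compound 1 to compound 2 (0.36 log units; beyond the scatter), exchanges the whole aromatic group on the carbon with the double bond to nitrogen and bears on the present step only indirectly: it shows that changes at this end of the molecule move the number in this assay by a modest amount, while no measured pair isolates a substituent on the phenyl ring itself. With nothing in the series that speaks to a bromine on that ring, the expected step is a 1.2-fold lower number from compound 2 to compound 3 (0.09 log units; within the scatter), that is, no change beyond the scatter, and the range is kept wide to reflect the absence of a direct precedent. Compound 3 is therefore estimated at 1500 nM, with a range from 600 nM to 4000 nM.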

Compound 3, half-maximal inhibitory concentration: 970 nM
For compound 3 the middle estimate is 1.5-fold (0.19 log units) above the measured one; the measured number falls inside the stated range.
By their numbers in this assay, from the lowest: compounds 1, 3 and 2 (each within the scatter of the next, the first and the last beyond it).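

Working notes on the phenyl end of the series. In this assay, among the compounds shown here, the first reading of a substituent on the phenyl ring itself is a 1.9-fold lower number from compound 2 to compound 3 (0.28 log units; within the scatter); 3-bromophenyl in place of phenyl is therefore not separated from the unsubstituted ring by this read-out. The second new comparison is a 1.2-fold higher number from compound 1 to compound 3 (0.07 log units; within the scatter), so the 3-bromophenyl group cannot be told from 1H-indol-3-yl either, although a 2.3-fold higher number from compound 1 to compound 2 (0.36 log units; beyond the scatter) does separate phenyl from 1H-indol-3-yl; compound 3 thus lies within the scatter of both compounds, and its place among them stays unresolved. Nothing available explains these numbers or ties them to any property of the bromo group.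

As far as these compounds go, it remains open whether any substituent on this aromatic carbon, such as an amine, a methoxy group or a carboxylic acid, would give a step beyond the scatter from compound 2. Also open, from the compounds shown here alone, is whether bromo elsewhere on the same ring would read the same as in compound 3, since a single substituent at a single place cannot define a trend for this ring.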